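The source may report more compounds than this note shows. Statements on the series, on what has been measured and on what is new or still open speak of the compounds shown alone.

Measured compounds:
Compound 1 `Cc1cc(Cc2ccccc2)c(=O)n(CC(=O)Nc2ccc(Br)cc2)n1` — in an assay on HL-60 cells for agonist activity at N-formyl peptide receptor 3 (Homo sapiens), read by calcium flux (on this read-out higher numbers stand for an effect only at larger amounts of compound and lower numbers for an effect already at smaller amounts), compound 1 gives only a limit of the assay, > 50000 nM.
Compound 2 `Cc1cc(Cc2ccsc2)c(=O)n(CC(=O)Nc2ccc(Br)cc2)n1` — in this assay compound 2 gives only a limit, > 50000 nM.
Compound 3 `Cc1cc(Cc2cccnc2)c(=O)n(CC(=O)Nc2ccc(Br)cc2)n1` — in this assay compound 3 gives only a limit, > 50000 nM.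

Compound 3 therefore stands at the same limit as its two companions; no number is known for it. The three steps among the measured compounds, a step that the two limits leave unreadable from compound 1 to compound 2, a step that the two limits leave unreadable from compound 1 to compound 3 and a step that the two limits leave unreadable from compound 2 to compound 3, cannot be read, because of the limit of > 50000 nM in this assay, at which 3 of the 3 values shown sit.

Compound 4 `Cc1cc(Cc2ccc(C#N)cc2)c(=O)n(CC(=O)Nc2ccc(Br)cc2)n1` has not yet been measured. It differs from compound 3 in one place: 4-cyanophenyl in place of pyridin-3-yl on a saturated chain carbon bound to an aromatic carbon. The measured steps that bear on this change are the three above, and none of them yields a size or a direction, so no expectation of a step beyond the scatter can be drawn from them in this assay. Going by the values given here, the only guidance is that every exchange of this group so far has left the compound at the limit.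

The estimate for compound 4 is 50000 nM, within 15000 nM to 200000 nM, and the step from compound 3 to compound 4 is expected to be a number no higher from compound 3 to compound 4 (the limit leaves the size open).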

Compound 4, half-maximal effective concentration: > 50000 nM
Compound 4: no number, only a limit; the forecaster's own chance of this, stated with the estimate: 80%; the middle value sits exactly at the limit.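

In this assay compound 4 gives > 50000 nM as a limit, not a number. Its steps from compound 1, compound 2 and compound 3 cannot be read, because all four compounds stop at the same limit: the limit of > 50000 nM in this assay, at which 4 of the 4 values shown sit. The compounds shown leave open whether any group at this place gives a measurable effect in this assay.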